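Swapping a bromobenzyl for a fluorophenyl on the piperazine

The source may report more compounds than this note shows. Statements on the series, on what has been measured and on what is new or still open speak of the compounds shown alone.

Of the compounds shown here, three sharing one core have been measured in an assay on CHO cells for displacement of a labelled ligand from adenosine receptor A2b (Homo sapiens), read by scintillation counting, with a stated time of 75 min, in the presence of a further agent that is not named here; on this read-out lower numbers stand for stronger inhibition and higher numbers for weaker inhibition. Compound 1 `CCCn1c(=O)[nH]c2nc(-c3ccc(S(=O)(=O)N4CCN(Cc5cccc(C)c5)CC4)cc3)[nH]c2c1=O` gives 0.397 nM, compound 2 `CCCn1c(=O)[nH]c2nc(-c3ccc(S(=O)(=O)N4CCN(c5cccc(Cl)c5)CC4)cc3)[nH]c2c1=O` gives 0.342 nM, and compound 3 `CCCn1c(=O)[nH]c2nc(-c3ccc(S(=O)(=O)N4CCN(Cc5cccc(Br)c5)CC4)cc3)[nH]c2c1=O` gives 0.148 nM, the lowest of the three numbers. The step of a 1.2-fold lower number from compound 1 to compound 2 (0.06 log units; within the scatter) lies within the scatter, whereas a 2.3-fold lower number from compound 2 to compound 3 (0.36 log units; beyond the scatter) and a 2.7-fold lower number from compound 1 to compound 3 (0.43 log units; beyond the scatter) are modest but real. Compound 4 `CCCn1c(=O)[nH]c2nc(-c3ccc(S(=O)(=O)N4CCN(c5ccccc5F)CC4)cc3)[nH]c2c1=O` differs from compound 3 by 2-fluorophenyl in place of 3-bromobenzyl on an amine nitrogen in a ring. Like compound 2, it carries the aromatic ring directly on the ring nitrogen, and the earlier step of a 2.3-fold lower number from compound 2 to compound 3 (0.36 log units; beyond the scatter) suggests that returning to such an arrangement costs a little. The number for compound 4 is therefore expected to rise modestly, a 2.4-fold higher number from compound 3 to compound 4 (0.37 log units; beyond the scatter). In this assay compound 4 is estimated at 0.35 nM, within a range from 0.12 nM to 1 nM.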

Compound 4, inhibition constant: 3.22 nM
Estimate against measurement, compound 4: 9.2-fold (0.96 log units) below; the measured number lies above the stated range.
By their numbers in this assay, from the lowest: compound 3; then compounds 2 and 1 (each within the scatter of the next); then compound 4.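

In this assay, going by these compounds alone, this ring nitrogen proves far less forgiving than the first three compounds suggested, with a 22-fold higher number from compound 3 to compound 4 (1.34 log units; beyond the scatter) as the largest step so far. An aromatic ring directly on the nitrogen does not settle the outcome: a 9.4-fold higher number from compound 2 to compound 4 (0.97 log units; beyond the scatter) still separates two such compounds, and an 8.1-fold higher number from compound 1 to compound 4 (0.91 log units; beyond the scatter) is also beyond the scatter. Nothing measured here gives a reason for this drop.

As far as these compounds go, whether the drop follows the fluorine itself or where it sits on the ring stays open. A plain phenyl or a 2-chlorophenyl on the same nitrogen would help separate the two.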